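A Longer Acid Chain on a Limit Compound

This account rests on a few compounds, and the source may have more. Where it says the series, first, only, none or still open, it means among the compounds named here.

Compound 1 `O=C(O)CCCCCCCCn1nc(-c2ccccc2)c(-c2ccccc2)c1-c1ccccc1`: 400 nM
Compound 2 `O=C(O)CCCCCCn1cc(-c2ccccc2)c(-c2ccccc2)n1`: > 92000 nM (a limit)

Within the data shown here, only two compounds have been tested in a functional assay for inhibition, with Homo sapiens as the target (a lower number here means a stronger inhibitor, a higher number a weaker inhibitor), and only one of them gave a number. Compound 2 is recorded at > 92000 nM, which is a limit of the assay and not a number. Its true position is therefore unknown.

Compound 3 `O=C(O)CCCCCCCCn1cc(-c2ccccc2)c(-c2ccccc2)n1` has not yet been measured. It differs from compound 2 by 2-carboxyethyl in place of carboxy on a saturated chain carbon, six bonds along the chain from an aromatic nitrogen, with 2-carboxyethyl in place of carboxy on a saturated chain carbon, six bonds along the chain from an aromatic nitrogen.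

Compound 1, at 400 nM, shows that a value in the measurable range is possible in this set. A large step towards stronger inhibition is therefore expected, though another limit remains possible. The expected step is an at least 30-fold lower number from compound 2 to compound 3 (1.48 log units; beyond the scatter). In this assay, the estimated value for compound 3 is 3000 nM, with an expected range of 400 nM to 30000 nM.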

Compound 3, half-maximal inhibitory concentration: 4500 nM
Compound 3: the middle estimate sits 1.5-fold (0.18 log units) below what was measured; measured number inside the range.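

In this assay, 2-carboxyethyl in place of carboxy on this saturated chain carbon moves the series from a limit to a measured number, with an at least 20-fold lower number from compound 2 to compound 3 (1.31 log units; beyond the scatter). That step gives only a minimum size, since compound 2 is recorded at a limit and not a number: the limit of > 92000 nM in this assay, at which 1 of the 3 values shown sits.

With the acid chain now the same in both compounds, the phenyl group can be read on its own: hydrogen in place of phenyl on an aromatic carbon gives an 11-fold higher number from compound 1 to compound 3 (1.05 log units; beyond the scatter), so the longer chain alone does not reach the level of compound 1.

As far as these compounds go, whether a still longer chain, or an amide in place of the carboxylic acid, would lower the number further stays open. From the compounds shown here alone, it is also open whether a smaller group on that aromatic carbon, such as methyl, could stand in for phenyl.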